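Replacing the Bromobenzyl Arm with a Short Allyl Chain

The compounds below may be only part of what the source reports. "The series", "measured", "known", "first", "only" and "open" are said of these compounds alone.

Compound 1 `Cc1cc(Nc2cc(-c3ccccc3)[nH]n2)n2ncnc2n1`: 21700 nM in a functional assay on MGC-803 cells (Homo sapiens) for inhibition, read by MTT assay, with a stated time of 72 h; a lower number here means a stronger inhibitor, a higher number a weaker inhibitor.
Compound 2 `Cc1cc(Nc2cc(-c3ccccc3)[nH]n2)n2nc(SCCc3ccccc3)nc2n1`: 5620 nM.
Compound 3 `Cc1cc(Nc2cc(-c3ccccc3)[nH]n2)n2nc(SCc3ccc(Br)cc3)nc2n1`: 1110 nM.

Compound 3 has the lowest number of the three, with compound 2 nearest at a 5.1-fold lower number from compound 2 to compound 3 (0.70 log units; beyond the scatter) and compound 1 furthest at a 20-fold lower number from compound 1 to compound 3 (1.29 log units; beyond the scatter). Compound 4 `C=CCSc1nc2nc(C)cc(Nc3cc(-c4ccccc4)[nH]n3)n2n1` differs from compound 3 in one place: vinyl in place of 4-bromophenyl on a saturated chain carbon bound to a sulfur. Among the measured compounds shown here, two measured steps bear on this change. Attaching a sulfur-linked group to the bare core gave a 3.9-fold lower number from compound 1 to compound 2 (0.59 log units; beyond the scatter), and exchanging benzyl for 4-bromophenyl gave a 5.1-fold lower number from compound 2 to compound 3 (0.70 log units; beyond the scatter). Compound 4 keeps a sulfur-linked group but carries no ring there, so a higher number is expected because a 5.1-fold lower number from compound 2 to compound 3 (0.70 log units; beyond the scatter) shows the ring mattered. Compound 4 is estimated at 8000 nM, within 2500 nM to 25000 nM, an expected step of a 7.2-fold higher number from compound 3 to compound 4 (0.86 log units; beyond the scatter).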

Compound 4, half-maximal inhibitory concentration: 17200 nM
For compound 4 the middle estimate is 2.2-fold (0.33 log units) below the measured one; the measured number falls inside the stated range.
By their numbers in this assay, from the lowest: compound 3; then compound 2; then compounds 4 and 1 (each within the scatter of the next).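

In this assay, a sulfur link alone is not enough: allylsulfanyl in place of hydrogen on the shared core leaves the number level (a 1.3-fold lower number from compound 1 to compound 4 (0.10 log units; within the scatter)). The gain depends on what lies beyond the sulfur, since vinyl in place of 4-bromophenyl costs far more (a 15-fold higher number from compound 3 to compound 4 (1.19 log units; beyond the scatter)) than vinyl in place of benzyl (a 3.1-fold higher number from compound 2 to compound 4 (0.49 log units; beyond the scatter)). Among these compounds, both ring-bearing arms give lower numbers than allyl.

As far as these compounds go, whether a plain benzyl or a longer propyl chain on the sulfur would track allyl or the ring-bearing arms stays open. No measurement shown gives a reason for these steps.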